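The source may hold more compounds than are shown below. What is called first, only, known or untested is meant among the compounds shown, and "the series" means these compounds.

Measured compounds in an assay on isolated protein for inhibition of 15-hydroxyprostaglandin dehydrogenase [NAD(+)] (Homo sapiens), read by fluorescence, with a stated time of 15 min; on this read-out lower numbers stand for stronger inhibition and higher numbers for weaker inhibition:
compound 1 `Cc1cc(-c2nnc3n2CCCCC3)c(C)n1-c1ccc(Br)cc1` gives 48 nM
compound 2 `COc1cccc(-n2cnc3cc(C(=O)N4CCCCC4)ccc32)c1` gives 19 nM
compound 3 `O=C(c1ccc2c(c1)ncn2-c1cccc(C(F)(F)F)c1)N1CCCCC1` gives 48 nM

Compound 3 stands level with compound 1 at the digits shown, and these two together sit at the high end of the three numbers. Going by the values given here, compound 2 is the only one set apart from it: the single measured step with one change, a 2.5-fold higher number from compound 2 to compound 3 (0.40 log units; beyond the scatter), shows that swapping methoxy for trifluoromethyl on an aromatic carbon of this core costs a modest amount in this assay.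

Compound 4 `CC(C)(C)c1cccc(-n2cnc3cc(C(=O)N4CCCCC4)ccc32)c1` differs from compound 3 by tert-butyl in place of trifluoromethyl on an aromatic carbon. Among the compounds with values here, no measured step swaps trifluoromethyl for tert-butyl, so the only step that bears on it, a 2.5-fold higher number from compound 2 to compound 3 (0.40 log units; beyond the scatter), is a change of a different group on an aromatic carbon and gives no direct guide to the direction. The groups leaving and entering match in atom count, ring content, donors, acceptors and charge, and nothing measured here ties a step of that kind to a shift beyond the scatter. The expectation for compound 4 is therefore a step of a 1.3-fold higher number from compound 3 to compound 4 (0.10 log units; within the scatter), which is within the scatter. Compound 4 is estimated at 60 nM, with a range from 20 nM to 180 nM.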

Compound 4, half-maximal inhibitory concentration: 171 nM
Beside the measured number, compound 4's estimate is 2.9-fold (0.45 log units) below it, within the range that was stated.
By their numbers in this assay, from the lowest: compound 2; then compounds 1 and 3 (each within the scatter of the next); then compound 4.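

In this assay, this place, on an aromatic carbon of a six-membered aromatic ring of carbon only and meta to a large group, responds even to a swap between groups that match in heavy atoms, ring content, donors, acceptors and charge, with a 3.6-fold higher number from compound 3 to compound 4 (0.55 log units; beyond the scatter) lying beyond the scatter. Going by these compounds alone, with a third group now on this carbon, the numbers rise in the order methoxy, trifluoromethyl, tert-butyl, and the whole span is a 9.0-fold higher number from compound 2 to compound 4 (0.95 log units; beyond the scatter), wider than the single step seen before, a 2.5-fold higher number from compound 2 to compound 3 (0.40 log units; beyond the scatter). No measured property of these groups is available to account for the shift.

The compounds shown leave open where a hydroxyl, an amine or a carboxylic acid on this carbon would fall relative to methoxy, the group with the lowest number so far. They also leave open whether the same order of the three groups would hold on another carbon of that ring, while compound 1 differs from the others in more than one place and cannot be placed in this order.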